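The compounds below may be only part of what the source reports. "The series", "measured", "known", "first", "only" and "open" are said of these compounds alone.

Measured compounds:

Compound 1, `N#CC/C(=C(/c1ccc(O)cc1)c1ccc(OCCN)cc1)c1ccccc1` — 48.9 nM
Compound 2, `NCCOc1ccc(C(=C(c2ccccc2)c2ccccc2)c2ccc(O)cc2)cc1` — 1930 nM
Compound 3, `CC/C(=C(/c1ccc(O)cc1)c1ccc(CCCN)cc1)c1ccc(O)cc1` — 491 nM

In an assay on isolated protein for inhibition of Aromatase (Homo sapiens), read by fluorescence, with a stated time of 30 min (on this read-out higher numbers stand for weaker inhibition and lower numbers for stronger inhibition), compound 1 gives 48.9 nM, the lowest of the three numbers. Compound 3 gives 491 nM, a value beyond the scatter from compound 1, and compound 2 gives 1930 nM, further still. Compound 1 is therefore the strongest inhibitor of the three shown here.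

Compound 4, `NCCOc1ccc(/C(=C(\CCCl)c2ccccc2)c2ccc(O)cc2)cc1`, has not yet been measured in this assay. It differs from compound 1 in one place: chloromethyl in place of cyano on a saturated chain carbon bound to a double-bonded chain carbon. Among the compounds with values here, no measured pair shows this same change, so the size of the step is uncertain; the expectation is a small step toward a weaker number, from compound 1 to compound 4, likely close to the scatter rather than far beyond it, expressed as a 1.8-fold higher number from compound 1 to compound 4 (0.26 log units; within the scatter). On that basis compound 4 is expected to give about 90 nM in this assay, within a range from 30 nM to 300 nM.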

Compound 4, half-maximal inhibitory concentration: 143 nM
The estimate for compound 4 lay 1.6-fold (0.20 log units) below the measured number, within the range that was stated.
By their numbers in this assay, from the lowest: compound 1; then compound 4; then compound 3; then compound 2.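

Replacing cyano with chloromethyl on a saturated chain carbon bound to a double-bonded chain carbon gives a 2.9-fold higher number from compound 1 to compound 4 (0.47 log units; beyond the scatter) in this assay, so this position responds to the group it carries, though only modestly. Read one bond further out, this is cyanomethyl giving way to 2-chloroethyl; each leaving and entering group counts 2 heavy atoms, while the triple bond and the 1 hydrogen-bond acceptor of cyano are lost. No measurement shown here accounts for the step.

With a single pair spanning this position, the compounds cannot show how far the response extends. Going by these compounds, whether an amine, a carboxylic acid or a longer chain ending in cyano would sit closer to compound 1 or to compound 4 remains open.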